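Fluoro for Chloro, Tried Again on a Low Starting Point

This account rests on a few compounds, and the source may have more. Where it says the series, first, only, none or still open, it means among the compounds named here.

Compound 1 `COc1ccc(Cc2nnc(NC(=O)/C(C#N)=C/c3ccccc3OS(=O)(=O)c3ccc(Cl)cc3)s2)cc1` and compound 2 `COc1ccc(Cc2nnc(NC(=O)/C(C#N)=C/c3ccccc3OS(=O)(=O)c3ccc(F)cc3)s2)cc1` differ only by fluoro in place of chloro on an aromatic carbon. In an ADME assay on HEK-293T cells (Homo sapiens) for inhibition, read by CCK-8 assay, with a stated time of 48 h, tested at 20 uM (a higher number here means more inhibition of growth at the concentration tested, a lower number less inhibition of growth), compound 1 gives 34%, while compound 2 gives 6%, a step of a number 28 percentage points lower from compound 1 to compound 2 (beyond the scatter). Compound 3 `N#C/C(=C\c1ccccc1OS(=O)(=O)c1ccc(Cl)cc1)C(=O)Nc1nnc(Cc2ccc(F)cc2)s1` has a different core, differing from compound 1 by fluoro in place of methoxy on an aromatic carbon; in this assay compound 3 gives 6%, which is a step of a number 28 percentage points lower from compound 1 to compound 3 (beyond the scatter). Compound 4 `N#C/C(=C\c1ccccc1OS(=O)(=O)c1ccc(F)cc1)C(=O)Nc1nnc(Cc2ccc(F)cc2)s1` differs from compound 3 by fluoro in place of chloro on an aromatic carbon, the same change that separates compound 1 from compound 2. Compound 3 already sits near the bottom of the scale, so the earlier drop cannot repeat in full; for compound 4 the expected step is a number 3 percentage points lower from compound 3 to compound 4 (within the scatter). Compound 4 is thus expected at about 3%, likely between -8% and 14%, because compound 3 gives only 6%.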

Compound 4, percent growth inhibition at one concentration: "not toxic" (no number reported)
Nothing numeric was reported for compound 4; the estimate stays without a comparison.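

Among the compounds shown here, compound 4 is reported only as "not toxic", with no number, so no step from compound 3 to compound 4 can be read. No evidence shown bears on this result. From the compounds shown here alone, whether fluoro in place of chloro changes growth inhibition on the core of compound 3 stays open.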